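Methoxy to ethoxy on a benzylidene enone

The source may report more compounds than this note shows. Statements on the series, on what has been measured and on what is new or still open speak of the compounds shown alone.

Measured in a functional assay on KB cells (Homo sapiens) for antiproliferative activity, read by sulforhodamine B assay, with a stated time of 72 h; on this read-out higher numbers stand for weaker inhibition and lower numbers for stronger inhibition:

Compound 1 `COc1ccc(/C=C2\CCC=CC2=O)cc1` gives 1560 nM
Compound 2 `COc1cccc(/C=C2\CCC=CC2=O)c1` gives 1550 nM
Compound 3 `COc1ccc(/C=C2\CCC=CC2=O)cc1OC` gives 900 nM

These three numbers lie close together. Compound 3 cannot be clearly separated from either of the other two, since both of its measured steps stay within the usual scatter of repeated measurements.

Compound 4 `CCOc1ccc(/C=C2\CCC=CC2=O)cc1OC` has not yet been measured. It differs from compound 3 by methyl in place of hydrogen on a saturated chain carbon bound to an oxygen on an aromatic ring. In words, this is methyl in place of hydrogen on a saturated chain carbon bound to an oxygen on an aromatic ring, which turns a methoxy into an ethoxy.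

Among the measured compounds shown here, no measured pair makes this exact change. The nearest evidence is methoxy in place of hydrogen on an aromatic carbon, seen as a 1.7-fold lower number from compound 1 to compound 3 (0.24 log units; within the scatter) and as a 1.7-fold lower number from compound 2 to compound 3 (0.24 log units; within the scatter). Those steps add a whole methoxy, yet neither rises above the scatter. The smaller change from methoxy to ethoxy is therefore not expected to shift this assay much in either direction. The estimated step is a 1.1-fold higher number from compound 3 to compound 4 (0.05 log units; within the scatter), which is expected to stay within the scatter. For compound 4 the expected value is 1000 nM, with an estimated range from 450 nM to 2200 nM.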

Compound 4, half-maximal inhibitory concentration: 1280 nM
For compound 4 the middle estimate is 1.3-fold (0.11 log units) below the measured one; low and high end bracket the measured number.
By their numbers in this assay, from the lowest: compounds 3, 4, 2 and 1 (each within the scatter of the next).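

Methyl in place of hydrogen on a saturated chain carbon bound to an oxygen on an aromatic ring turns a methoxy into an ethoxy, and in this assay this gives a 1.4-fold higher number from compound 3 to compound 4 (0.15 log units; within the scatter), so at this position the longer group cannot be told apart from the shorter one. Among the compounds shown here, the other new step is a 1.2-fold lower number from compound 2 to compound 4 (0.08 log units; within the scatter), which means that adding a whole ethoxy also produces no clear separation, just as adding a whole methoxy did among the earlier compounds. No measurement at hand offers any explanation for the size of these small steps.

From the compounds shown here alone, it remains open whether a longer chain on this oxygen, such as propoxy or butoxy, would stay equally close, or whether an amine or a carboxylic acid at the end of that chain would produce a step beyond the scatter. The compounds shown also leave open what a hydroxy group would do here, and whether turning the remaining methoxy of compound 4 into a second ethoxy would make any clear difference.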